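The source may report more compounds than this note shows. Statements on the series, on what has been measured and on what is new or still open speak of the compounds shown alone.

Two compounds of the series have numbers in a functional assay, with a stated time of 60 min, tested at 0.5 mM; a higher number here means a stronger effect of the compound at the concentration tested, a lower number a weaker effect. Compound 1 `Cn1c(=O)c(C(=O)NCCCCCCN)c(O)c2ccccc21` gives 21.9%, and compound 2 `NCCCCCCNC(=O)c1c(O)c2ccccc2n(-c2ccccc2)c1=O` gives 28.1%. For the measured compounds named here, compound 1 stands lowest of the two, with compound 2 nearest, and the only measured step, a number 6.2 percentage points higher from compound 1 to compound 2 (within the scatter), lies within the scatter. Compound 3 `Cn1c(=O)c(C(=O)NCCCCCCNC(=O)CCCCC2CCSS2)c(O)c2ccccc21` is not yet measured. It differs from compound 1 by a group of 11 heavy atoms (8 carbon, 1 oxygen, 2 sulfur; one five-membered non-aromatic ring with 2 hetero atoms) in place of a hydrogen atom, on an amine nitrogen. Going by the values given here, no measured step touches an amine nitrogen; the one step known, phenyl in place of methyl on an aromatic nitrogen, stayed within the scatter and does not bear on this change. Nothing in the series therefore points to a step beyond the scatter in either direction, and the range has to stay wide. For compound 3 the estimate in this assay is 25%, between 5% and 50%, which means an expected step of a number 3.1 percentage points higher from compound 1 to compound 3 (within the scatter).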

Compound 3, a percentage reported as activity, at one concentration (the size of the read-out at that concentration, not a potency): 38.8%
Compound 3: the middle estimate sits 13.8 percentage points below what was measured, within the range that was stated.
By their numbers in this assay, from the lowest: compounds 1 and 2 (each within the scatter of the next); then compound 3.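

In this assay, for the compounds shown here, the amine nitrogen is the first place where a change moves the read-out beyond the scatter: a number 16.9 percentage points higher from compound 1 to compound 3 (beyond the scatter), a modest step. Going by these compounds alone, the only earlier step, phenyl in place of methyl on an aromatic nitrogen, stayed within the scatter, whereas this nitrogen takes a group of 11 heavy atoms in place of a hydrogen atom with a gain rather than a loss, so the hydrogen on it is not needed for the read-out at the concentration tested. Nothing available accounts for the gain.

Open, from the compounds shown here alone, is which part of the entering group carries the step: the carbonyl and chain or the five-membered ring with its 2 sulfur atoms, a question that an acetyl group or a plain alkyl amide on the same nitrogen would address. Also open, going by these compounds, is whether the same group gives a similar step on the core of compound 2, which has phenyl on the aromatic nitrogen.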